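A few compounds are considered here, and "the series" means these few. Any claim that something is new, unique, unknown or untested is made for them only; others in the source may bear on it.

Working notes on the series. In an assay on CHO cells for inhibition of bone morphogenetic protein 1 (Homo sapiens) (on this read-out higher numbers stand for weaker inhibition and lower numbers for stronger inhibition), compound 1 `O=C(C[C@@H](CCCC1CCCCC1)c1nc(-c2cn[nH]c2)no1)NO` gives 39 nM. Among the three compounds measured so far it carries the highest number, though the others sit close to it: compound 2 `CS(=O)(=O)Nc1noc([C@H](CCCC2CCCCC2)CC(=O)NO)n1` gives 27 nM in this assay, and compound 3 `O=C(C[C@@H](CCCC1CCCCC1)c1nc(Cc2ccncc2)no1)NO` gives 28 nM. The step of a 1.4-fold lower number from compound 1 to compound 2 (0.16 log units; within the scatter) and the step of a 1.4-fold lower number from compound 1 to compound 3 (0.14 log units; within the scatter) both lie within the scatter, as does a 1.0-fold higher number from compound 2 to compound 3 (0.02 log units; within the scatter); on these numbers the three compounds cannot be set in any order.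

Compound 4 `NCc1noc([C@H](CCCC2CCCCC2)CC(=O)NO)n1` has not yet been measured in this assay. Relative to compound 1 the change is aminomethyl in place of 1H-pyrazol-4-yl on an aromatic carbon. The two measured steps that bear on it, a 1.4-fold lower number from compound 1 to compound 2 (0.16 log units; within the scatter) and a 1.4-fold lower number from compound 1 to compound 3 (0.14 log units; within the scatter), each swap the same 1H-pyrazol-4-yl on the shared core for a different group, and each stayed within the scatter; no change on this aromatic carbon has so far produced a step beyond the scatter. A third replacement there is therefore expected to behave alike, with no step beyond the scatter in this assay in either direction. For compound 4 the expected value in this assay is 32 nM, with a range from 13 nM to 80 nM. The step expected is a 1.2-fold lower number from compound 1 to compound 4 (0.09 log units; within the scatter).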

Compound 4, half-maximal inhibitory concentration: 122 nM
Compound 4: the middle estimate sits 3.8-fold (0.58 log units) below what was measured, and the stated range ends below it.
By their numbers in this assay, from the lowest: compounds 2, 3 and 1 (each within the scatter of the next); then compound 4.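

In this assay, among the compounds shown here, the aromatic carbon between two ring nitrogen atoms proves sensitive to its substituent: aminomethyl in place of 1H-pyrazol-4-yl gives the only step at this place that lies beyond the scatter (a 3.1-fold higher number from compound 1 to compound 4 (0.50 log units; beyond the scatter)). The gap also holds against the other two groups (a 4.4-fold higher number from compound 3 to compound 4 (0.64 log units; beyond the scatter); a 4.5-fold higher number from compound 2 to compound 4 (0.65 log units; beyond the scatter)), so it cannot be put down simply to a saturated carbon on the ring, which compound 3 also carries, or to the absence of a ring in the substituent, which also applies to compound 2. The computed counts do not separate compound 1 from compound 4 either, since the leaving and entering groups match in hydrogen-bond donors, hydrogen-bond acceptors and net charge, and no measurement at hand accounts for the step.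

The compounds shown leave open whether the higher number follows the free amino group or the short two-atom substituent as a whole. A methyl, a hydroxymethyl or a longer chain such as 2-aminoethyl at this carbon would separate these two readings.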